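Swapping the pyridyl amide of compound 3 for a methoxyacetamide

The compounds below may be only part of what the source reports. "The series", "measured", "known", "first", "only" and "open" are said of these compounds alone.

Of the compounds shown here, three sharing one core have been measured in a functional assay on KBVIN cells (Homo sapiens) for antiproliferative activity, read by sulforhodamine B assay, with a stated time of 3 days; on this read-out higher numbers stand for weaker inhibition of growth and lower numbers for stronger inhibition of growth. Compound 1 `COc1ccc(NC(=O)c2cccc(Nc3ncc(F)c(Nc4ccc(F)cc4)n3)c2)cc1` gives 15700 nM, and compound 2 `O=C(Nc1cc(Cl)cc(Cl)c1)c1cccc(Nc2ncc(F)c(Nc3ccc(F)cc3)n2)c1` gives 20700 nM; the step of a 1.3-fold higher number from compound 1 to compound 2 (0.12 log units; within the scatter) separates them. Within the data shown here, compound 3 `O=C(Nc1cccc(Nc2ncc(F)c(Nc3ccc(F)cc3)n2)c1)c1ccncc1`, in which the amide is turned around so that the ring nitrogen carries an acyl group, gives 4570 nM, the lowest of the three numbers and the only one whose steps to both others lie beyond the scatter: a 3.4-fold lower number from compound 1 to compound 3 (0.54 log units; beyond the scatter) and a 4.5-fold lower number from compound 2 to compound 3 (0.66 log units; beyond the scatter).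

Compound 4 `COCC(=O)Nc1cccc(Nc2ncc(F)c(Nc3ccc(F)cc3)n2)c1` keeps that acylamino arrangement and alters only the acyl group: methoxymethyl in place of pyridin-4-yl on a carbonyl carbon. Among the measured compounds shown here, no measured pair addresses this kind of change directly. The two steps that reach compound 3 report that the inverted amide bearing an aromatic acyl group is the better arrangement, but they say nothing about what an open-chain acyl group does in that position. With the aromatic ring gone and a small ether chain in its place, a modest upward movement in this assay is thought plausible, though a result within the scatter cannot be ruled out. Compound 4 is therefore expected to give 8000 nM, within a range from 2500 nM to 25000 nM, which corresponds to an expected step of a 1.8-fold higher number from compound 3 to compound 4 (0.24 log units; within the scatter).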

Compound 4, concentration for 50% growth inhibition: 3940 nM
For compound 4 the middle estimate is 2.0-fold (0.31 log units) above the measured one, within the range that was stated.
By their numbers in this assay, from the lowest: compounds 4 and 3 (each within the scatter of the next); then compounds 1 and 2 (each within the scatter of the next).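

In this assay, methoxymethyl in place of pyridin-4-yl on the carbonyl carbon gives a 1.2-fold lower number from compound 3 to compound 4 (0.06 log units; within the scatter), so at this position the acyl group need not carry an aromatic ring: an open-chain group with fewer heavy atoms and no ring reads the same within the scatter. The separation from the two compounds with the amide the other way round also survives the change, with a 4.0-fold lower number from compound 1 to compound 4 (0.60 log units; beyond the scatter) and a 5.3-fold lower number from compound 2 to compound 4 (0.72 log units; beyond the scatter), so those lower numbers are not tied to the pyridin-4-yl group. Nothing measured here accounts for why these two different acyl groups read alike.

Going by these compounds, it remains open what an aminomethyl group, a carboxylic acid or a longer ether chain on this carbonyl carbon would do, and whether any acyl group here can move the number beyond the scatter of compound 3 and compound 4. The compounds shown also pair no single group with both orientations of the amide, so the contribution of the orientation itself cannot be separated from that of the groups it carries.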